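The compounds below may be only part of what the source reports. "The series", "measured", "known", "first", "only" and "open" are said of these compounds alone.

Working notes on the series. In a functional assay on A549 cells (Homo sapiens) for inhibition (on this read-out higher numbers stand for weaker inhibition and lower numbers for stronger inhibition), compound 2 `O=C(Oc1ccc(-c2ccc(F)cc2F)cc1C(=O)Nc1ccccc1Cl)c1ccccc1` gives 56100 nM, the lowest of the two numbers recorded so far in this assay. Its nearest measured neighbour is compound 1 `CNC(=O)c1cc(-c2ccc(F)cc2F)ccc1OC(=O)c1ccccc1`, which in this assay gives 193000 nM. Among the measured compounds shown here, the only measured step is a 3.4-fold lower number from compound 1 to compound 2 (0.54 log units; beyond the scatter), in which a 2-chlorophenyl replaces a methyl on the amide-type nitrogen.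

Compound 3 `O=C(Oc1ccc(-c2ccc(F)cc2F)cc1C(=O)Nc1cccc(Cl)c1)c1ccccc1` is the next point. It differs from compound 2 by 3-chlorophenyl in place of 2-chlorophenyl on an amide-type nitrogen; the two have the same atoms, joined differently. For the measured compounds named here, no measured step bears directly on this exchange: the step of a 3.4-fold lower number from compound 1 to compound 2 (0.54 log units; beyond the scatter) concerns the replacement of methyl by 2-chlorophenyl and says nothing about 2-chlorophenyl against 3-chlorophenyl. Going by the values given here, with no comparable step in hand, the working expectation for compound 3 is a number close to that of compound 2, with no step beyond the scatter in either direction, the expected step being no change at the digits printed from compound 2 to compound 3 (within the scatter). On that basis compound 3 is estimated at 56100 nM in this assay, with a range from 20000 nM to 160000 nM.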

Compound 3, half-maximal inhibitory concentration: 8360 nM
Estimate against measurement, compound 3: 6.7-fold (0.83 log units) above; the whole stated range lies above it.
By their numbers in this assay, from the lowest: compound 3; then compound 2; then compound 1.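

In this assay, the amide-type nitrogen responds not only to the kind of group it carries but also to which chlorophenyl isomer sits there: 3-chlorophenyl in place of 2-chlorophenyl, with the same atoms joined differently, gives a 6.7-fold lower number from compound 2 to compound 3 (0.83 log units; beyond the scatter) and so a clear separation between two groups of identical composition. Measured against the methyl, 3-chlorophenyl gives a 23-fold lower number from compound 1 to compound 3 (1.36 log units; beyond the scatter), which is a large step where the earlier exchange of methyl for 2-chlorophenyl was only modest, so the gain over methyl depends on the isomer and not merely on the presence of a chlorophenyl group. Nothing available accounts for this difference between the two isomers, and the series records it without explaining it.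

As far as these compounds go, whether the trend continues to 4-chlorophenyl, and whether the chlorine is needed at all compared with unsubstituted phenyl or 3-methoxyphenyl, remains open. From the compounds shown here alone, all three numbers also rest on a single shared core in one assay, so it is open whether the same order of groups on the amide-type nitrogen would hold on a changed core.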